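The compounds below may be only part of what the source reports. "The series", "measured", "known", "first", "only" and "open" are said of these compounds alone.

Compound 1 `COc1ccc(C(=O)C2Sc3nnc(-c4cc(OC)c(OC)c(OC)c4)n3NC2c2ccco2)cc1` gives > 100000 nM
Compound 2 `COc1cc(-c2nnc3n2NC(c2ccco2)C(C(=O)c2cccs2)S3)cc(OC)c1OC` gives 64100 nM
Compound 3 `COc1cc(-c2nnc3n2NC(c2ccco2)C(C(=O)c2ccccc2)S3)cc(OC)c1OC` gives 90900 nM

In a functional assay on HepG2 cells (Homo sapiens) for cytotoxicity, read by MTT assay, with a stated time of 48 h (on this read-out higher numbers stand for weaker inhibition and lower numbers for stronger inhibition), compound 1 yields only a limit, not a number: it sits at the limit of > 100000 nM in this assay, at which 1 of the 3 values shown sits. Compound 4 `COc1cc(-c2nnc3n2NC(c2ccco2)C(C(=O)c2ccc(O)cc2)S3)cc(OC)c1OC` differs from compound 1 by hydrogen in place of methyl on an oxygen on an aromatic ring, which reads further out as methoxy to hydroxy, (4-methoxyphenyl)carbonyl to (4-hydroxyphenyl)carbonyl. The two measured steps that leave compound 1, an at least 1.5-fold lower number from compound 1 to compound 2 (0.19 log units; that floor lies within the scatter) and an at least 1.1-fold lower number from compound 1 to compound 3 (0.04 log units; that floor lies within the scatter), alter the carbonyl substituent in other ways, and both begin from a limit, so their floors stay within the scatter. For the measured compounds named here, no measured step trades methyl for hydrogen on oxygen. The expected step is a number no higher from compound 1 to compound 4 (the limit leaves the size open), none beyond the scatter. Compound 4 is estimated at 100000 nM, in a range from 40000 nM to 250000 nM, with a fair chance that only a limit is reported again.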

Compound 4, half-maximal inhibitory concentration: > 100000 nM
Compound 4: no number, only a limit; the forecaster's own chance of this, stated with the estimate: 55%; the middle value sits exactly at the limit.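

In this assay compound 4 gives only a limit, as compound 1 does, so the step from methoxy to hydroxy cannot be read: the limit of > 100000 nM in this assay, at which 2 of the 4 values shown sit. Against the compounds with numbers only floors appear, all within the scatter: an at least 1.1-fold higher number from compound 3 to compound 4 (0.04 log units; that floor lies within the scatter) and an at least 1.5-fold higher number from compound 2 to compound 4 (0.19 log units; that floor lies within the scatter). Thus hydroxy, like methoxy, gives no number here, and neither group shows an advantage over hydrogen or thiophen-2-yl in place of the substituted phenyl.

Going by these compounds, the true size of the methoxy to hydroxy step stays open. So does whether an amine or a carboxylic acid in place of that hydroxy would give a number at all.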